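Isopropyl in Place of an Aryl Group on Compound 1

A few compounds are considered here, and "the series" means these few. Any claim that something is new, unique, unknown or untested is made for them only; others in the source may bear on it.

Measured compounds:
compound 1, `COc1ccc(N/C(CCNC2=CC(=O)c3ccccc3C2=O)=N\S(=O)(=O)c2ccc(C)cc2)cc1`, 12000 nM
compound 2, `Cc1ccc(S(=O)(=O)/N=C(/CCNC2=CC(=O)c3ccccc3C2=O)Nc2ccc(F)c(F)c2)cc1`, 12900 nM
compound 3, `COc1cc(N/C(CCNC2=CC(=O)c3ccccc3C2=O)=N\S(=O)(=O)c2ccc(C)cc2)cc(OC)c1OC`, 9330 nM

In a functional assay on DU-145 cells (Homo sapiens) for cytotoxicity, read by MTT assay, with a stated time of 48 h (on this read-out lower numbers stand for stronger inhibition and higher numbers for weaker inhibition), compound 1 stands second highest of the three numbers. Its nearest neighbour is compound 2, reached by a 1.1-fold higher number from compound 1 to compound 2 (0.03 log units; within the scatter), and its furthest is compound 3, reached by a 1.3-fold lower number from compound 1 to compound 3 (0.11 log units; within the scatter). The remaining pair gives a 1.4-fold lower number from compound 2 to compound 3 (0.14 log units; within the scatter). All three steps therefore sit within the scatter, and the three compounds cannot be ordered on these data.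

Compound 4, `Cc1ccc(S(=O)(=O)/N=C(/CCNC2=CC(=O)c3ccccc3C2=O)NC(C)C)cc1`, differs from compound 1 in one place: isopropyl in place of 4-methoxyphenyl on an amine nitrogen. Every measured step exchanges one aromatic substituent on that amine nitrogen for another, and none of them moves the number beyond the scatter. Going by the values given here, no measured step replaces an aromatic group with a chain such as isopropyl, so the change in compound 4 has no direct precedent here. Given that the aryl swaps left this assay essentially unchanged, the step to compound 4 is expected to be small, a 1.2-fold higher number from compound 1 to compound 4 (0.07 log units; within the scatter), with a wider range to reflect the absent precedent. Compound 4 is estimated at 14000 nM, between 5000 nM and 40000 nM.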

Compound 4, half-maximal inhibitory concentration: 28500 nM
Beside the measured number, compound 4's estimate is 2.0-fold (0.31 log units) below it; the range from low to high includes it.
By their numbers in this assay, from the lowest: compounds 3, 1 and 2 (each within the scatter of the next); then compound 4.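

Going by these compounds alone, on the amine nitrogen, where swaps among aromatic substituents stayed within the scatter, leaving the aromatic series for isopropyl produces the first change beyond it in this assay (a 2.4-fold higher number from compound 1 to compound 4 (0.38 log units; beyond the scatter); a 2.2-fold higher number from compound 2 to compound 4 (0.34 log units; beyond the scatter); a 3.1-fold higher number from compound 3 to compound 4 (0.48 log units; beyond the scatter)). Within the data shown here, all three steps are modest and point the same way, so compound 4 gives weaker inhibition than each aryl compound, and no compound among the four goes against this. Nothing shown here accounts for the shift.

Compound 4 loses the aromatic ring and also carries fewer heavy atoms, so the compounds shown cannot separate these two changes. A cyclohexyl group or a longer chain such as n-butyl on the same amine nitrogen would bear on that question.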